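Swapping Methyl for Chloro on a Piperazine Benzyl Arm

This account rests on a few compounds, and the source may have more. Where it says the series, first, only, none or still open, it means among the compounds named here.

Measured so far:
- compound 1, `CN(C)/C=C/N1CCN(CC(=O)Nc2ccc(-c3nc(-c4ccccc4)c(-c4ccccc4)n3C)cc2)CC1`: 1.2% in a functional assay on MCF7 cells (Homo sapiens) for cytotoxicity, read by MTT assay, with a stated time of 24 h, tested at 0.64 ug/mL; on this read-out higher numbers stand for a stronger effect at the one concentration tested and lower numbers for a weaker effect
- compound 2, `Cc1ccc(CN2CCN(CC(=O)Nc3ccc(-c4nc(-c5ccccc5)c(-c5ccccc5)n4C)cc3)CC2)cc1`: 9.4%

Both numbers are small. On paper the number of compound 2 is the larger of the two, but the step of a number 8.2 percentage points higher from compound 1 to compound 2 (within the scatter) lies within the scatter, so the two compounds cannot be told apart in this assay.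

Compound 3, `Cn1c(-c2ccc(NC(=O)CN3CCN(Cc4ccc(Cl)cc4)CC3)cc2)nc(-c2ccccc2)c1-c1ccccc1`, differs from compound 2 by chloro in place of methyl on an aromatic carbon. Within the data shown here, the only measured step, from compound 1 to compound 2, replaced the whole group on the ring nitrogen and still stayed within the scatter; no measured step touches a substituent on the benzyl ring itself. Nothing in the data therefore points to a shift beyond the scatter in this assay.

Compound 3 is expected to give about 10%, between 0% and 25%. The expected step is a number 0.6 percentage points higher from compound 2 to compound 3 (within the scatter), nothing beyond the scatter.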

Compound 3, a percentage reported as activity, at one concentration (the size of the read-out at that concentration, not a potency): 4.8%
The estimate for compound 3 lay 5.2 percentage points above the measured number; the measured number falls inside the stated range.
By their numbers in this assay, from the lowest: compounds 1, 3 and 2 (each within the scatter of the next).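

Chloro in place of methyl, para to a large group, is the first change on the benzyl ring itself, and it gives a number 4.6 percentage points lower from compound 2 to compound 3 (within the scatter) in this assay so this swap cannot be told apart from no change. The 4-chlorobenzyl group in place of 2-(dimethylamino)ethenyl on the amine nitrogen in the ring gives a number 3.6 percentage points higher from compound 1 to compound 3 (within the scatter) in this assay so, as with 4-methylbenzyl, this larger replacement also leaves no readable difference. No supporting measurement bears on this result.

From the compounds shown here alone, what an amine or a carboxylic acid on that same aromatic carbon would give remains open. So does whether these compounds would separate at any concentration other than the single one tested here.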